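Bromophenyl ethylidene hydrazone in place of methylbenzylidene

The source may hold more compounds than are shown below. What is called first, only, known or untested is meant among the compounds shown, and "the series" means these compounds.

Compound 1 `CCCSc1nc(N/N=C/c2ccc(C)cc2)c2nnn(Cc3ccccc3)c2n1` sits at the limit of a functional assay on MCF7 cells (Homo sapiens) for antiproliferative activity, read by MTT assay, with a stated time of 72 h (a lower number here means a stronger inhibitor, a higher number a weaker inhibitor), giving > 64000 nM, which is a limit and not a number (the limit of > 64000 nM in this assay, at which 1 of the 3 values shown sits). Compound 2 `CCCSc1nc(N/N=C/c2ccc(N(C)C)cc2)c2nnn(Cc3ccccc3)c2n1` gives 12200 nM and compound 3 `CCCSc1nc(N/N=C/c2c[nH]c3ccccc23)c2nnn(Cc3ccccc3)c2n1` gives 9010 nM in this assay. The two measured steps both lower the number: an at least 5.2-fold lower number from compound 1 to compound 2 (0.71 log units; beyond the scatter) and an at least 7.1-fold lower number from compound 1 to compound 3 (0.85 log units; beyond the scatter). Compound 4 `CCCSc1nc(N/N=C(\C)c2ccc(Br)cc2)c2nnn(Cc3ccccc3)c2n1` differs from compound 1 at the hydrazone: a group of 10 heavy atoms (8 carbon, 1 nitrogen, 1 bromine; one six-membered aromatic ring of carbon only) in place of a group of 9 heavy atoms (8 carbon, 1 nitrogen; one six-membered aromatic ring of carbon only), on a nitrogen on an aromatic ring. Within the data shown here, the entering group carries a bromine, which no measured step covers. A lower number is expected in this assay, though the limit on compound 1 leaves the size open. Compound 4 is expected at 30000 nM, with a range of 8000 nM to 100000 nM. That implies an expected step of an at least 2.1-fold lower number from compound 1 to compound 4 (0.32 log units; beyond the scatter).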

Compound 4, half-maximal inhibitory concentration: 13000 nM
The estimate for compound 4 lay 2.3-fold (0.36 log units) above the measured number, within the range that was stated.
By their numbers in this assay, from the lowest: compounds 3, 2 and 4 (each within the scatter of the next). At a limit, above all of these: compound 1.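

In this assay, among these compounds, the bromine-bearing group on this nitrogen gives an at least 4.9-fold lower number from compound 1 to compound 4 (0.69 log units; beyond the scatter), the first step here that brings in a bromine. Compound 2, compound 3 and compound 4 now carry three different groups at this place, and their values lie within the scatter of one another. Compound 1 stands at a limit and not a number: the limit of > 64000 nM in this assay, at which 1 of the 4 values shown sits.

The step changes the bromophenyl and the ethylidene together, so neither can be read alone. On these data alone, how a carboxylic acid or a morpholine on the phenyl ring would read stays open.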